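The source may hold more compounds than are shown below. What is called first, only, known or untested is meant among the compounds shown, and "the series" means these compounds.

Three compounds share one core and differ only in the group attached to a carbonyl carbon on the ring nitrogen. Compound 1 `COCC(=O)N1CCC(NS(=O)(=O)c2ccc(NC(=O)c3ccccc3C)c3ccccc23)CC1` gives 15.8 nM in an assay on L1.2 cells for binding affinity to C-C chemokine receptor type 8 (Homo sapiens); on this read-out lower numbers stand for stronger inhibition and higher numbers for weaker inhibition. Compound 2 `Cc1ccccc1C(=O)Nc1ccc(S(=O)(=O)NC2CCN(C(N)=O)CC2)c2ccccc12` gives 243 nM in this assay. Compound 3 `Cc1ccccc1C(=O)Nc1ccc(S(=O)(=O)NC2CCN(C(=O)NC(C)C)CC2)c2ccccc12` gives 77.7 nM in this assay, the second highest of the three numbers, set by a 3.1-fold lower number from compound 2 to compound 3 (0.50 log units; beyond the scatter) and by a 4.9-fold higher number from compound 1 to compound 3 (0.69 log units; beyond the scatter). Compound 4 `Cc1ccccc1C(=O)Nc1ccc(S(=O)(=O)NC2CCN(C(=O)N3CCCC3)CC2)c2ccccc12` carries pyrrolidin-1-yl in place of isopropylamino on a carbonyl carbon. The step that bears most on it is a 3.1-fold lower number from compound 2 to compound 3 (0.50 log units; beyond the scatter), where a group added on that nitrogen brought a modest fall, while a 15-fold higher number from compound 1 to compound 2 (1.19 log units; beyond the scatter) shows how much the group at this position can matter. A further modest fall is therefore expected, though a ring is new here. Compound 4 is expected to give 40 nM, between 15 nM and 120 nM, which would mean a 1.9-fold lower number from compound 3 to compound 4 (0.29 log units; within the scatter).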

Compound 4, inhibition constant: 1.1 nM
The estimate for compound 4 lay 36-fold (1.56 log units) above the measured number; measured number outside the range, below it.
By their numbers in this assay, from the lowest: compound 4; then compound 1; then compound 3; then compound 2.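

Among these compounds, putting pyrrolidin-1-yl in place of isopropylamino gives a 71-fold lower number from compound 3 to compound 4 (1.85 log units; beyond the scatter) in this assay, showing that this carbonyl substituent can change binding far more than the earlier compounds suggested. The same group gives a 220-fold lower number from compound 2 to compound 4 (2.34 log units; beyond the scatter) and a 14-fold lower number from compound 1 to compound 4 (1.16 log units; beyond the scatter) and so also surpasses methoxymethyl, the best earlier group. The change both adds a five-membered ring and removes a hydrogen-bond donor, and no measurement here explains the gain. Still open, as far as these compounds go, is which of those two differences matters. Dimethylamino and piperidin-1-yl on the same carbonyl carbon would help separate them.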